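Hydrogen for Methyl on an Aromatic Nitrogen

This account rests on a few compounds, and the source may have more. Where it says the series, first, only, none or still open, it means among the compounds named here.

Measured so far:
compound 1 `CC(C)Oc1cc(-c2cncc(-c3nn[nH]n3)c2)ccc1C(N)=O` gives 310 nM in an assay on cells for inhibition of MAP kinase-interacting serine/threonine-protein kinase 1 (Homo sapiens), read by mobility shift assay, with stated times of 10 min and 60 min, in the presence of a further agent that is not named here; a lower number here means a stronger inhibitor, a higher number a weaker inhibitor
compound 2 `Cc1c(-c2cncc(-c3ccc(C(N)=O)c(OC(C)C)c3)c2)cnn1C` gives 60 nM in this assay

For the measured compounds named here, compound 2 stands at the lowest of the two numbers, with compound 1 as its only neighbour. Going by the values given here, the single measured step, a 5.2-fold lower number from compound 1 to compound 2 (0.71 log units; beyond the scatter), came with 1,5-dimethyl-1H-pyrazol-4-yl in place of 2H-tetrazol-5-yl on an aromatic carbon, a modest gain.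

Compound 3 `Cc1[nH]ncc1-c1cncc(-c2ccc(C(N)=O)c(OC(C)C)c2)c1` differs from compound 2 by hydrogen in place of methyl on an aromatic nitrogen. Among the compounds with values here, no measured step bears on this change: the one step available swaps the whole five-membered ring rather than a substituent on it, so it gives no guide for hydrogen in place of methyl on an aromatic nitrogen. The change is small in size, and a step of the order of the scatter or little beyond it is expected, with no clear direction. Compound 3 is therefore estimated to give 80 nM in this assay, between 30 nM and 250 nM, which means an expected step of a 1.3-fold higher number from compound 2 to compound 3 (0.12 log units; within the scatter).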

Compound 3, half-maximal inhibitory concentration in the MAP kinase-interacting serine/threonine-protein kinase 1 assay: 54 nM
Compound 3: the middle estimate sits 1.5-fold (0.17 log units) above what was measured; the range from low to high includes it.
By their numbers in the MAP kinase-interacting serine/threonine-protein kinase 1 assay, from the lowest: compounds 3 and 2 (each within the scatter of the next); then compound 1.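

In the MAP kinase-interacting serine/threonine-protein kinase 1 assay, the methyl on this aromatic nitrogen proves dispensable, with hydrogen in its place giving a 1.1-fold lower number from compound 2 to compound 3 (0.05 log units; within the scatter), and the 5-methyl-1H-pyrazol-4-yl group still stands clear of 2H-tetrazol-5-yl, at a 5.7-fold lower number from compound 1 to compound 3 (0.76 log units; beyond the scatter). In a physicochemical assay for solubility, measured as thermodynamic solubility, at pH 7.4 (a lower number here means a less soluble compound, a higher number a more soluble compound), compound 2 gives 7.3 ug/mL and compound 3 gives 11 ug/mL, which amounts to a 1.5-fold higher number from compound 2 to compound 3 (0.18 log units; within the scatter), so the change shows no effect beyond the scatter in either assay. No evidence is available that would explain these results.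

The compounds shown leave open whether this nitrogen would tolerate something larger than methyl, such as an ethyl group, a longer chain or a chain ending in an amine. They also leave open how much the methyl on the neighbouring ring atom contributes, since hydrogen or trifluoromethyl at that place has no reading here.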